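This account rests on a few compounds, and the source may have more. Where it says the series, first, only, none or still open, it means among the compounds named here.

In a functional assay on MCF7 cells (Homo sapiens) for inhibition, read by sulforhodamine B assay (a higher number here means a weaker inhibitor of growth, a lower number a stronger inhibitor of growth), compound 3 `Cc1ccc2[nH]c(-c3ccc(-c4ccc(-c5ccccc5)cc4)cc3)nc2c1` gives 31600 nM. Compound 2 `Fc1ccc(-c2ccc(-c3ccc(-c4nc5ccccc5[nH]4)cc3)cc2)cc1` gives 36200 nM, which lies within the scatter of compound 3. Compound 1 `Cc1ccc2[nH]c(-c3ccc(-c4ccc(-c5ccc(N(C)C)cc5)cc4)cc3)nc2c1` gives 3130 nM, a lower number well beyond the scatter of compound 3.

The change to compound 4 `Cc1ccc2[nH]c(-c3ccc(-c4ccc(-c5ccc(F)cc5)cc4)cc3)nc2c1` is fluoro in place of hydrogen on an aromatic carbon, para to a large group, turning phenyl into 4-fluorophenyl.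

Going by the values given here, the only measured step that bears on this change is a 10-fold higher number from compound 1 to compound 3 (1.00 log units; beyond the scatter), with hydrogen in place of dimethylamino. It is a modest step, but it involves a different group and does not give the size of a fluoro change. The closest guide is compound 2, which also carries 4-fluorophenyl and gives 36200 nM. No step beyond the scatter is therefore expected in this assay, and neither direction is favoured. The expected step is a 1.1-fold lower number from compound 3 to compound 4 (0.02 log units; within the scatter). For compound 4 the estimated value is 30000 nM, with an expected range of 13000 nM to 70000 nM.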

Compound 4, concentration for 50% growth inhibition: 30200 nM
Estimate against measurement, compound 4: 1.0-fold (0.00 log units) below, within the range that was stated.
By their numbers in this assay, from the lowest: compound 1; then compounds 4, 3 and 2 (each within the scatter of the next).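

In this assay, fluoro in place of hydrogen on the aromatic carbon para to a large group gives a 1.0-fold lower number from compound 3 to compound 4 (0.02 log units; within the scatter) and so leaves the number unmoved at this position. With 4-fluorophenyl in both compounds, the methyl that compound 4 carries on the core and compound 2 lacks gives a 1.2-fold lower number from compound 2 to compound 4 (0.08 log units; within the scatter) and likewise moves nothing. Fluoro in place of dimethylamino gives a 9.6-fold higher number from compound 1 to compound 4 (0.98 log units; beyond the scatter) and matches in kind the hydrogen step a 10-fold higher number from compound 1 to compound 3 (1.00 log units; beyond the scatter), so among these groups only dimethylamino separates a compound from the rest.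

On these data alone, whether another amine, such as morpholine, or a carboxylic acid at this position would shift the number as dimethylamino does remains open. No measurement here accounts for the lower number of compound 1 or for the flat fluoro step.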